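N-Methoxy Replacement on the Amide Nitrogen of a Thiophene Amide

The source may report more compounds than this note shows. Statements on the series, on what has been measured and on what is new or still open speak of the compounds shown alone.

Measured compounds:
compound 1, `Cc1ccc(OCC(=O)N(CCO)Cc2cccs2)cc1`, 900 nM
compound 2, `Cc1ccc(OCC(=O)N(Cc2cccs2)c2ccccn2)cc1`, 200 nM
compound 3, `COCCN(Cc1cccs1)C(=O)COc1ccc(C)cc1`, 400 nM

All three share a core and differ only in the group on the amide-type nitrogen. In an assay on HEK293 cells for agonist activity at transient receptor potential cation channel subfamily M member 8 (Homo sapiens), read by fluorescence and calcium flux, with a stated time of 15 min (a lower number here means that less compound is needed, a higher number that more compound is needed for the effect), compound 3 gives 400 nM, the second highest of the three numbers. Its nearest neighbour is compound 2, with a 2.0-fold higher number from compound 2 to compound 3 (0.30 log units; within the scatter), a gap within the scatter, so no order between compounds 2 and 3 can be claimed. Compound 1 stands further away, with a 2.3-fold lower number from compound 1 to compound 3 (0.35 log units; beyond the scatter).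

Compound 4, `CON(Cc1cccs1)C(=O)COc1ccc(C)cc1`, is the next member. The change from compound 3 is methoxy in place of 2-methoxyethyl on an amide-type nitrogen. For the measured compounds named here, of the measured steps, the one from compound 1 to compound 3, a 2.3-fold lower number from compound 1 to compound 3 (0.35 log units; beyond the scatter), is the only one that touches the oxygen of this chain, and it is modest; the step from compound 2 to compound 3 shows that a different group on this nitrogen left the number within the scatter. Going by the values given here, no measured step removes two carbons of the chain, so the effect of the shortening itself is unknown. The expected step is therefore small, a 1.5-fold higher number from compound 3 to compound 4 (0.18 log units; within the scatter), leaning towards a slightly higher number. Compound 4 is expected to give 600 nM, within a range of 200 nM to 2000 nM.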

Compound 4, half-maximal effective concentration: 10 nM
Beside the measured number, compound 4's estimate is 60-fold (1.78 log units) above it; measured number below the stated range.
By their numbers in this assay, from the lowest: compound 4; then compounds 2 and 3 (each within the scatter of the next); then compound 1.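

In this assay, for the compounds shown here, this position on the amide-type nitrogen proves far more sensitive than the earlier compounds showed: replacing 2-methoxyethyl with methoxy gives a large change (a 40-fold lower number from compound 3 to compound 4 (1.60 log units; beyond the scatter)), whereas the earlier steps among the 2-hydroxyethyl, pyridin-2-yl and 2-methoxyethyl groups were modest or within the scatter. The result holds against both other groups, with methoxy in place of pyridin-2-yl (a 20-fold lower number from compound 2 to compound 4 (1.30 log units; beyond the scatter)) and in place of 2-hydroxyethyl (a 90-fold lower number from compound 1 to compound 4 (1.95 log units; beyond the scatter)), so compound 4 has the lowest number of the four by a margin beyond the scatter in every comparison. The counts do not track this change, since methoxy and 2-methoxyethyl carry the same numbers of hydrogen-bond donors and acceptors and neither has a net charge, leaving the smaller heavy-atom count as the only counted difference.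

The compounds shown do not separate the shorter group from its different attachment to the nitrogen, and a comparison with an ethyl or an ethoxy group at this place would be needed to tell these apart. What lies behind the large step remains unexplained, as no supporting measurement bears on it.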